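Swapping methyl for methoxy on the aryl ring

The source may report more compounds than this note shows. Statements on the series, on what has been measured and on what is new or still open speak of the compounds shown alone.

Of the compounds shown here, three sharing one core have been tested in a functional assay on HeLa cells (Homo sapiens) for inhibition, read by MTT assay, with a stated time of 24 h; on this read-out lower numbers stand for stronger inhibition and higher numbers for weaker inhibition. Compound 1 `CCOC(=O)C1=Cc2ccccc2OC1(OCc1cn(CC(=O)Nc2cccc(Cl)c2)nn1)C(F)(F)F` carries a triazole-linked amide; in this assay compound 1 gives 12300 nM. Compound 2 `CCOC(=O)C1=Cc2ccccc2OC1(OCc1cc(-c2ccc(C)cc2)no1)C(F)(F)F` instead carries an isoxazole bearing a 4-methylphenyl group. In this assay compound 2 gives only a limit, > 150000 nM, and no number, so its standing is known only as the limit of > 150000 nM in this assay, at which 1 of the 3 values shown sits. Compound 3 `Cc1ccc(-c2cc(COC3(C(F)(F)F)Oc4ccccc4C=C3C(=O)O)on2)cc1` differs from compound 2 by hydrogen in place of ethyl on an oxygen next to a carbonyl group, and in this assay compound 3 gives 33400 nM, a step of an at least 4.4-fold lower number from compound 2 to compound 3 (0.65 log units; beyond the scatter).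

Compound 4 `CCOC(=O)C1=Cc2ccccc2OC1(OCc1cc(-c2ccc(OC)cc2)no1)C(F)(F)F` is the next candidate. It differs from compound 2 by methoxy in place of methyl on an aromatic carbon, so the 4-methylphenyl group becomes 4-methoxyphenyl while the ester stays. Among the measured compounds shown here, the only measured step from compound 2 concerns the ester, not this ring, so no measured step bears on the change. Compound 4 is therefore expected to sit where compound 2 sits, with a step of a number no higher from compound 2 to compound 4 (the limit leaves the size open), and in this assay compound 4 is estimated at 150000 nM (range 50000 nM to 400000 nM).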

Compound 4, half-maximal inhibitory concentration: > 150000 nM
Compound 4 gave a limit, no number (the forecaster's own chance of this, stated with the estimate: 60%); the middle value sits exactly at the limit.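

Compound 2 and compound 4 both give a limit rather than a number, so no step between them can be read: the limit of > 150000 nM in this assay, at which 2 of the 4 values shown sit.

As far as these compounds go, whether 4-methoxyphenyl and 4-methylphenyl differ in inhibition stays open, as does whether hydrogen in place of ethyl would give compound 4 a measurable number, as it does for compound 2.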